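The compounds below may be only part of what the source reports. "The series", "measured", "known", "first", "only" and "open" are said of these compounds alone.

Compound 1, `COc1ccc(/C=C2\Cc3c(cc(OC)c(OC)c3OC)C2=O)cc1O`, was assessed in a functional assay on PC-3 cells (Homo sapiens) for antiproliferative activity, read by MTT assay, with a stated time of 48 h (a higher number here means a weaker inhibitor of growth, a lower number a stronger inhibitor of growth), where compound 1 gives 213 nM. Compound 2, `COc1ccc(/C=C2\Cc3c(cc(OC)c(OC)c3OC)C2=O)cc1OC`, differs from it by methyl in place of hydrogen on an oxygen on an aromatic ring, and in this assay compound 2 gives 7470 nM; the change brings a 35-fold higher number from compound 1 to compound 2 (1.54 log units; beyond the scatter). Compound 3, `COc1cc2c(cc1O)C(=O)/C(=C/c1ccc(OC)c(OC)c1OC)C2`, carries the same atoms as compound 1 joined differently; the difference between the two cores is not broken down here. In this assay compound 3 gives 3140 nM. Compound 4, `COc1cc2c(cc1OC)C(=O)/C(=C/c1ccc(OC)c(OC)c1OC)C2`, differs from compound 3 by methyl in place of hydrogen on an oxygen on an aromatic ring, the same change as that from compound 1 to compound 2, made at the same kind of place. Within the data shown here, for compound 4 a weakening step of a 13-fold higher number from compound 3 to compound 4 (1.11 log units; beyond the scatter) is expected, resting on the single earlier step of a 35-fold higher number from compound 1 to compound 2 (1.54 log units; beyond the scatter) between compound 1 and compound 2. Compound 4 is accordingly estimated at 40000 nM, with a range from 8000 nM to 200000 nM.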

Compound 4, concentration for 50% growth inhibition: > 10000 nM
Compound 4: a limit, no number; the forecaster's own chance of this, stated with the estimate: 25%; the middle value does not contradict the limit.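

In this assay compound 4 gives > 10000 nM, which is a limit of the assay and not a number. Replacing hydroxy by methoxy on the core of compound 3 gives an at least 3.1-fold higher number from compound 3 to compound 4 (0.50 log units; beyond the scatter), so the direction of the change seen on the core of compound 1 carries over to this second core. Its size cannot be said to carry over, and whether the step is smaller on this core remains undecided: the same change on two cores in this assay, a 35-fold higher number (1.54 log units; beyond the scatter) from compound 1 to compound 2 and an at least 3.1-fold higher number (0.50 log units; beyond the scatter) from compound 3 to compound 4; the limit leaves it open whether they differ

The compounds shown leave open how a longer chain such as ethoxy, or an amine in place of the hydroxy, would fare on either core. Among these compounds, with only two pairs carrying this change, its behaviour on any further core also remains open.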